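The source may hold more compounds than are shown below. What is called first, only, known or untested is meant among the compounds shown, and "the series" means these compounds.

Of the compounds shown here, three built on one shared core have been tested in a functional assay on HUVEC cells (Homo sapiens) for antiproliferative activity, read by MTT assay, with a stated time of 48 h; on this read-out lower numbers stand for stronger inhibition and higher numbers for weaker inhibition. Compound 1 `O=C(Nc1ccccc1)Nc1nnc(Sc2ncnc3scc(-c4ccncc4)c23)s1` gives 19300 nM, compound 2 `Cc1cccc(NC(=O)Nc2nnc(Sc3ncnc4scc(-c5ccncc5)c34)s2)c1` gives 12200 nM, and compound 3 `COc1ccc(NC(=O)Nc2nnc(Sc3ncnc4scc(-c5ccncc5)c34)s2)cc1` gives 16900 nM. Compound 2 shows the lowest of the three numbers, though both others sit within the scatter of it: a 1.6-fold lower number from compound 1 to compound 2 (0.20 log units; within the scatter) and a 1.4-fold higher number from compound 2 to compound 3 (0.14 log units; within the scatter), just as a 1.1-fold lower number from compound 1 to compound 3 (0.06 log units; within the scatter). Compound 4 `O=C(Nc1cccc(F)c1)Nc1nnc(Sc2ncnc3scc(-c4ccncc4)c23)s1` differs from compound 2 in a single place: fluoro in place of methyl on an aromatic carbon. For the measured compounds named here, every measured step so far concerns a small change at the same part of the molecule, and none moved the number beyond the scatter, so a further small change there is expected to do the same. For compound 4 the expected step is a 1.1-fold higher number from compound 2 to compound 4 (0.06 log units; within the scatter), giving an estimated 14000 nM, with a range from 7000 nM to 28000 nM.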

Compound 4, half-maximal inhibitory concentration: 13700 nM
The estimate for compound 4 lay 1.0-fold (0.01 log units) above the measured number, within the range that was stated.
By their numbers in this assay, from the lowest: compounds 2, 4, 3 and 1 (each within the scatter of the next).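

Fluorine on this aromatic carbon is the first atom tried there that is neither carbon nor hydrogen, yet both replacing methyl (a 1.1-fold higher number from compound 2 to compound 4 (0.05 log units; within the scatter)) and replacing hydrogen (a 1.4-fold lower number from compound 1 to compound 4 (0.15 log units; within the scatter)) stay within the scatter. The 3-fluorophenyl group also matches the 4-methoxyphenyl group (a 1.2-fold lower number from compound 3 to compound 4 (0.09 log units; within the scatter)), so four different phenyl groups on this nitrogen now give no step beyond the scatter. Nothing available explains this flat result. From the compounds shown here alone, whether an amine, a carboxylic acid or a longer chain on this phenyl ring would move the number remains open. So does the effect of changes elsewhere on the molecule.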